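Amide nitrogen substituent change, compound 1 to compound 4

The compounds below may be only part of what the source reports. "The series", "measured", "known", "first", "only" and "open" are said of these compounds alone.

Measured compounds:
compound 1 `COc1ccc2c(=O)c(/C=C/C(=O)Nc3ccccc3Cl)coc2c1`; in a functional assay on L02 cells (Homo sapiens) for inhibition, read by MTT assay, with a stated time of 48 h (a higher number here means a weaker inhibitor, a lower number a stronger inhibitor), compound 1 reaches only the assay limit > 200000 nM.
compound 2 `O=C(/C=C/c1coc2cc(O)ccc2c1=O)NCc1ccc(F)cc1`; in this assay compound 2 reaches only the assay limit > 200000 nM.
compound 3 `COc1ccc(NC(=O)/C=C/c2coc3cc(O)ccc3c2=O)cc1`; in this assay compound 3 reaches only the assay limit > 200000 nM.

Compound 1 stands at the limit of this assay and not at a number, and every value shown in the series sits at that same limit (the limit of > 200000 nM in this assay, at which 3 of the 3 values shown sit). No order among compound 1, compound 2 and compound 3 can be read from this. Among the compounds with values here, the one measured step on the amide-type nitrogen, a step that the two limits leave unreadable from compound 2 to compound 3, has limits at both ends and gives no size. Within the data shown here, compound 2 and compound 3 carry a hydroxy group where compound 1 carries a methoxy group on the shared core; no step across that pair is available, and both pairs of values simply sit at the limit.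

Compound 4 `COc1ccc(CNC(=O)/C=C/c2coc3cc(OC)ccc3c2=O)cc1` differs from compound 1 by 4-methoxybenzyl in place of 2-chlorophenyl on an amide-type nitrogen. Among the measured compounds shown here, no measured step bears readably on this change, so no step beyond the scatter is expected, and a number no higher from compound 1 to compound 4 (the limit leaves the size open) is the estimated outcome. For compound 4 in this assay the expected value is 200000 nM, within 100000 nM to 400000 nM, most probably again reported as a limit.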

Compound 4, half-maximal inhibitory concentration: > 200000 nM
Compound 4: only a limit was reported; the forecaster's own chance of this, stated with the estimate: 85%; the middle value lies on the limit itself.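

Compound 1 and compound 4 both stand at a limit and not at a number, so no step can be read between them. The compounds shown leave open whether any change on the amide-type nitrogen or the shared core moves the value in this assay, with all of them at one limit: the limit of > 200000 nM in this assay, at which 4 of the 4 values shown sit.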